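From isopropyl to 2-methoxyethyl on an aromatic nitrogen

The source may report more compounds than this note shows. Statements on the series, on what has been measured and on what is new or still open speak of the compounds shown alone.

Compound 1 `COCCn1cc(C(=O)C(=O)Nc2ccc(OCC(=O)O)nc2)c2ccccc21`, which also carries 2-methoxyethyl on an aromatic nitrogen, gives only a limit in a functional assay on FaDu cells (Homo sapiens) for cytotoxicity, read by MTT assay, with a stated time of 72 h (on this read-out higher numbers stand for lower toxicity in this test and lower numbers for higher toxicity in this test), > 10000 nM.

In this assay compound 2 `COc1ccc(NC(=O)C(=O)c2cn(C(C)C)c3ccccc23)cn1` gives 85 nM. Compound 3 `CC(C)Oc1ccc(NC(=O)C(=O)c2cn(C(C)C)c3ccccc23)cn1` gives 408 nM, the higher of the two actual numbers. Compound 4 `COCCn1cc(C(=O)C(=O)Nc2ccc(OC(C)C)nc2)c2ccccc21` has 2-methoxyethyl in place of isopropyl on an aromatic nitrogen. For the measured compounds named here, the only measured step, a 4.8-fold higher number from compound 2 to compound 3 (0.68 log units; beyond the scatter), is a modest one on an oxygen, not on this nitrogen, so it bears on the change only loosely. Going by the values given here, no measured step touches this nitrogen, so a small rise in this assay, within the scatter, is expected. The expected change is a 1.5-fold higher number from compound 3 to compound 4 (0.17 log units; within the scatter). Compound 4 is estimated at 600 nM, with an expected range of 120 nM to 3000 nM.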

Compound 4, concentration lethal to 50% of the cells: 55 nM
Beside the measured number, compound 4's estimate is 11-fold (1.04 log units) above it; measured number outside the range, below it.
By their numbers in this assay, from the lowest: compounds 4 and 2 (each within the scatter of the next); then compound 3. At a limit, above all of these: compound 1.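

For the compounds shown here, with 2-methoxyethyl in place of isopropyl on this aromatic nitrogen, this assay gives a 7.4-fold lower number from compound 3 to compound 4 (0.87 log units; beyond the scatter), the first measured step at this position. With 2-methoxyethyl held on that nitrogen, isopropyl in place of carboxymethyl on an oxygen on an aromatic ring gives an at least 180-fold lower number from compound 1 to compound 4 (2.25 log units; beyond the scatter). That step rests on a limit for compound 1, so its size is only a bound: the limit of > 10000 nM in this assay, at which 1 of the 4 values shown sits.

The compounds shown leave open whether the ether oxygen of 2-methoxyethyl or its chain length accounts for the step. On these data alone, how an amine or a hydroxyl at the end of this chain would read also stays open.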